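Working notes on cell tolerance across three analogues

This account rests on a few compounds, and the source may have more. Where it says the series, first, only, none or still open, it means among the compounds named here.

Within the data shown here, compound 1 `COc1ccc2c(OCC[C@@H]3NC(=O)N(C)CCCC/C=C\[C@@H]4C[C@@]4(C(=O)NS(=O)(=O)C4(C)CC4)NC3=O)cc(-c3nc(C(C)C)cs3)nc2c1Br` and compound 2 `CCC1(S(=O)(=O)NC(=O)[C@@]23C[C@H]2/C=C\CCCCN(C)C(=O)N[C@@H](CCOc2cc(-c4nc(C(C)C)cs4)nc4c(Cl)c(OC)ccc24)C(=O)N3)CC1` share the same core and differ in more than one place, so no single step joins them. In an ADME assay on cells (Homo sapiens) for activation (a higher number here means that more compound is tolerated, a lower number that less compound is tolerated), compound 1 gives 28300 nM and compound 2 gives 49300 nM. On the numbers shown compound 2 stands level with compound 1, the gap between them being within the scatter. Compound 3 `COc1ccc2c(OCC[C@@H]3NC(=O)N(C)CCCC/C=C\[C@@H]4C[C@@]4(C(=O)NS(=O)(=O)C4(C)CC4)NC3=O)cc(-c3nc(C(C)C)cs3)nc2c1Cl` has not yet been measured. It differs from compound 2 in one place: hydrogen in place of methyl on a saturated chain carbon bound to a saturated ring carbon; read one bond further out, (1-ethylcyclopropyl)sulfonyl becomes (1-methylcyclopropyl)sulfonyl. Among the measured compounds shown here, no measured step of this kind exists in the set, so the expectation rests only on the closeness of compound 1 and compound 2. The step of a 1.2-fold lower number from compound 2 to compound 3 (0.09 log units; within the scatter) is expected to stay within the scatter, with no set direction. For compound 3 the estimate in this assay is 40000 nM, with a range from 18000 nM to 90000 nM.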

Compound 3, half-maximal cytotoxic concentration: 37400 nM
For compound 3 the middle estimate is 1.1-fold (0.03 log units) above the measured one; measured number inside the range.
By their numbers in this assay, from the lowest: compounds 1, 3 and 2 (each within the scatter of the next).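

Compound 3 turns the two-place gap between compound 1 and compound 2 into two single changes that can be read separately. In this assay, (1-ethylcyclopropyl)sulfonyl to (1-methylcyclopropyl)sulfonyl gives a 1.3-fold lower number from compound 2 to compound 3 (0.12 log units; within the scatter) and stays within the scatter. Chloro in place of bromo on an aromatic carbon gives a 1.3-fold higher number from compound 1 to compound 3 (0.12 log units; within the scatter) and also stays within the scatter, so neither change, taken alone, separates its pair in this assay.

The compounds shown cover only ethyl and methyl on the cyclopropyl ring and only chloro and bromo on the aromatic carbon, so it remains open whether a longer chain, an amine or a carboxylic acid at the first place, or a methyl or nitrile at the second, would do the same. Nothing available here offers an explanation for either step.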